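A few compounds are considered here, and "the series" means these few. Any claim that something is new, unique, unknown or untested is made for them only; others in the source may bear on it.

Measured so far:
Compound 1, `Cc1cc(NCc2ccccn2)n2ncc(-c3cccc(Cl)c3)c2n1`: in a physicochemical assay for solubility, read by HPLC, using the shake flask method, measured as kinetic solubility, with a stated time of 2 h, at pH 7.4 (on this read-out higher numbers stand for higher solubility and lower numbers for lower solubility), compound 1 gives < 5000 nM, which is a limit of the assay and not a number.
Compound 2, `Cc1cc(NCc2ccc(F)cn2)n2nc(C)c(-c3ccccc3)c2n1`: in this assay compound 2 gives < 5000 nM, likewise a limit rather than a number.

Compound 1 therefore stands at the limit, and the other value shown does too: the limit of < 5000 nM in this assay, at which 2 of the 2 values shown sit. Among the measured compounds shown here, no step between compound 1 and compound 2 has been measured, and the two structures differ in more than one place, so their two readings show only that both sit at the limit.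

Compound 3, `Cc1cc(NCc2ccccn2)n2ncc(-c3ccc(O)cc3)c2n1`, is not yet measured. It differs from compound 1 in one place: 4-hydroxyphenyl in place of 3-chlorophenyl on an aromatic carbon. For the measured compounds named here, no step of this kind has been measured. Compound 1 gives only a limit, so the starting point itself is uncertain. The expectation in this assay is a rise of modest size, beyond the usual scatter, from compound 1 to compound 3, expressed as an at least 1.4-fold higher number from compound 1 to compound 3 (0.14 log units; that floor lies within the scatter). Compound 3 is expected to give 7000 nM, within 1500 nM to 30000 nM, with a fair chance that the assay again reports only a limit.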

Compound 3, solubility: 10900 nM
The estimate for compound 3 lay 1.6-fold (0.19 log units) below the measured number, and the stated range covers the measured number.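

At the aromatic carbon two ring bonds from the ring nitrogen, the aryl group is not tied to the limit: in this assay, 4-hydroxyphenyl in place of 3-chlorophenyl gives an at least 2.1-fold higher number from compound 1 to compound 3 (0.33 log units; beyond the scatter). This single exchange bundles several differences, since chlorine leaves, oxygen enters with the hydrogen-bond donor and acceptor counted for 4-hydroxyphenyl, and the substituent number on the ring also differs. The step is a floor and not a full size because compound 1 gives only a limit: the limit of < 5000 nM in this assay, at which 2 of the 3 values shown sit.

The compounds shown leave open whether the hydroxy group itself or its place on the ring goes with the higher number, as 3-hydroxyphenyl and 4-chlorophenyl on the core of compound 1 would be needed to separate the two. Also open, on these data alone, is how a carboxylic acid or an amine in place of the hydroxy group would read in this assay, and whether the same exchange on the core of compound 2 would give a step of like size.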